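The source may report more compounds than this note shows. Statements on the series, on what has been measured and on what is new or still open speak of the compounds shown alone.

The series shares one core, carried by compound 1 `O=c1ccc(CCCO)nn1Cc1ccccc1`, compound 2 `CC(C)(C)[Si](OCc1ccc(=O)[nH]n1)(c1ccccc1)c1ccccc1` and compound 3 `Cn1nc(CCCO[Si](c2ccccc2)(c2ccccc2)C(C)(C)C)ccc1=O`. In a functional assay on aorta (Rattus norvegicus) (a higher number here means a weaker inhibitor, a lower number a stronger inhibitor), compound 1 reaches only a limit of > 100000 nM. In this assay compound 2 gives 62600 nM. In this assay compound 3 likewise reaches only a limit of > 100000 nM. Compound 3 thus stands at the edge of what this assay reports, sharing that position with compound 1, as the limit of > 100000 nM in this assay, at which 2 of the 3 values shown sit, shows. Compound 4 `CC(C)(C)[Si](OCCCc1ccc(=O)[nH]n1)(c1ccccc1)c1ccccc1` has not yet been measured in this assay. It differs from compound 3 by hydrogen in place of methyl on an aromatic nitrogen. Within the data shown here, no measured pair of compounds records a step of this kind, so the only guide is compound 2, which also carries hydrogen on an aromatic nitrogen. Because compound 2 gives 62600 nM in this assay, compound 4 is expected to sit in the same weak region, with a step of an at least 1.4-fold lower number from compound 3 to compound 4 (0.15 log units; that floor lies within the scatter) that, if any, points toward stronger inhibition but may not exceed the scatter. Compound 4 is estimated at 70000 nM in this assay, between 30000 nM and 150000 nM, with a fair chance that only a limit is reported.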

Compound 4, half-maximal inhibitory concentration: 78300 nM
Estimate against measurement, compound 4: 1.1-fold (0.05 log units) below; the range from low to high includes it.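

Hydrogen in place of methyl on the aromatic nitrogen now has a readable size in this assay, with an at least 1.2-fold lower number from compound 3 to compound 4 (0.10 log units; that floor lies within the scatter). That size is only a floor, because compound 3 sits at a limit and not at a number: the limit of > 100000 nM in this assay, at which 2 of the 4 values shown sit. With hydrogen on that nitrogen, the group of 9 heavy atoms and the group of 7 heavy atoms are not told apart in this assay, with a 1.3-fold higher number from compound 2 to compound 4 (0.10 log units; within the scatter).

The compounds shown leave open whether an ethyl group on the aromatic nitrogen would read like the methyl or like the hydrogen. Also open, as far as these compounds go, is whether an amine or a carboxylic acid on the saturated chain would move the number beyond the scatter from those of compound 2 and compound 4.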